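Aryl exchange on the series: compound 3 to compound 4

A few compounds are considered here, and "the series" means these few. Any claim that something is new, unique, unknown or untested is made for them only; others in the source may bear on it.

Measured in a functional assay on MCF7 cells (Homo sapiens) for inhibition, read by MTT assay, with a stated time of 48 h; a higher number here means a weaker inhibitor of growth, a lower number a stronger inhibitor of growth:
compound 1 `Cn1cc(C2CC(c3ccccc3)=NN2C(=O)c2cccnc2)c2ccccc21` gives 7200 nM in this series
compound 2 `Cn1cc(C2CC(c3ccccc3)=NN2C(=O)c2cccnc2)c2cc(Br)ccc21` gives 1520 nM in this series
compound 3 `COc1ccc2c(c1)c(C1CC(c3ccc(Cl)cc3)=NN1C(=O)c1ccc(OC)nc1)cn2C` gives 3710 nM in this series

Compound 3 stands level with compound 1 within the scatter and above compound 2 beyond the scatter. Compound 4 `COc1cccc(C2=NN(C(=O)c3ccc(OC)nc3)C(c3cn(C)c4ccc(OC)cc34)C2)c1` has 3-methoxyphenyl in place of 4-chlorophenyl on a carbon with a double bond to nitrogen. Among the compounds with values here, the only measured step, a 4.7-fold lower number from compound 1 to compound 2 (0.68 log units; beyond the scatter), is bromo in place of hydrogen on an aromatic carbon. Within the data shown here, it is modest and a different change, so it bears only weakly, and no measured step covers this exchange. The expected result is a 1.1-fold lower number from compound 3 to compound 4 (0.03 log units; within the scatter), with no direction expected beyond the scatter. The estimate for compound 4 is 3500 nM (expected range 1500 nM to 8000 nM).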

Compound 4, concentration for 50% growth inhibition: 130 nM
Estimate against measurement, compound 4: 27-fold (1.43 log units) above; the whole stated range lies above it.
By their numbers in this assay, from the lowest: compound 4; then compound 2; then compounds 3 and 1 (each within the scatter of the next).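

The aryl group on the carbon with a double bond to nitrogen proves a sensitive point of the series in this assay, with a 29-fold lower number from compound 3 to compound 4 (1.46 log units; beyond the scatter) for 3-methoxyphenyl in place of 4-chlorophenyl. The earlier compounds shown here offered only a 4.7-fold lower number from compound 1 to compound 2 (0.68 log units; beyond the scatter) and so gave no reading at this position. Nothing at hand explains the size of the new step. Because the exchange alters both the group and where it sits on the phenyl ring, the compounds shown cannot separate these two changes. 3-Chlorophenyl and 4-methoxyphenyl at this carbon would tell them apart.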